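Benzyloxybenzoyl urea series: estimate for compound 4

This account rests on a few compounds, and the source may have more. Where it says the series, first, only, none or still open, it means among the compounds named here.

Measured compounds in a functional assay on HT-29 cells (Homo sapiens) for inhibition, read by MTT assay, with a stated time of 48 h; a lower number here means a stronger inhibitor, a higher number a weaker inhibitor:
compound 1 `O=C(NC(=S)Nc1ccc(Cl)c(-c2nc3ccccc3[nH]2)c1)c1ccc(OCc2ccc(C(F)(F)F)cc2)cc1` gives 12900 nM
compound 2 `O=C(NC(=S)Nc1ccc(Cl)c(-c2nc3ccccc3[nH]2)c1)c1ccc(OCc2ccc(Cl)cc2Cl)cc1` gives 6080 nM
compound 3 `Cc1ccc(NC(=O)NC(=O)c2ccc(OCc3cccc(C(F)(F)F)c3)cc2)cc1-c1nc2ccccc2[nH]1` gives 3520 nM

Compound 3 has the lowest number of the three, but its gap to compound 2 lies within the scatter; only its gap to compound 1 is beyond it. Compound 4 `Cc1ccc(NC(=O)NC(=O)c2ccc(OCc3ccc(F)cc3)cc2)cc1-c1nc2ccccc2[nH]1` differs from compound 3 in one place: 4-fluorophenyl in place of 3-(trifluoromethyl)phenyl on a saturated chain carbon bound to an oxygen on an aromatic ring. Going by the values given here, the only measured step that touches the same place is a 2.1-fold lower number from compound 1 to compound 2 (0.33 log units; beyond the scatter), which swapped one substituted phenyl for another on the benzyloxy carbon in the thiourea core. That step was modest, and it involved different substituents and a different core than the change from compound 3 to compound 4, so it gives only a rough guide to the size of the move and none to its direction. For compound 4 a small shift is therefore expected, of about a 1.4-fold higher number from compound 3 to compound 4 (0.15 log units; within the scatter), with no confident direction beyond the scatter. Compound 4 is estimated at 5000 nM, in the range 1800 nM to 14000 nM.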

Compound 4, half-maximal inhibitory concentration: 980 nM
Beside the measured number, compound 4's estimate is 5.1-fold (0.71 log units) above it; measured number below the stated range.
By their numbers in this assay, from the lowest: compound 4; then compounds 3 and 2 (each within the scatter of the next); then compound 1.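

On the core shared by compound 3 and compound 4, the group on a saturated chain carbon bound to an oxygen on an aromatic ring changes the result in this assay with nothing else altered: a 3.6-fold lower number from compound 3 to compound 4 (0.56 log units; beyond the scatter). This position therefore now has a step beyond the scatter on this core as well as on the core of compound 1, although the two steps involve different groups and give no common trend. Nothing available accounts for the step from 3-(trifluoromethyl)phenyl to 4-fluorophenyl.

The change replaces both the substituent and its place on the phenyl ring, so the contribution of each remains unresolved. As far as these compounds go, it is also open how this core would respond to 3-fluorophenyl, 4-(trifluoromethyl)phenyl, or an amine or carboxylic acid on the phenyl ring.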